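Allyl to isopropyl on the charged nitrogen of an aminoalkyl carboxylate

The compounds below may be only part of what the source reports. "The series", "measured", "known", "first", "only" and "open" are said of these compounds alone.

Compound 1 `CC[N+](C)(C)NCCC(=O)[O-]`: 140000 nM
Compound 2 `C=CC[N+](C)(C)NCCC(=O)[O-]`: 119000 nM

In an assay for inhibition of gamma-butyrobetaine dioxygenase (Homo sapiens), read by HPLC, with stated times of 15 min and 30 min (a higher number here means a weaker inhibitor, a lower number a stronger inhibitor), compound 2 gives 119000 nM, the lower of the two numbers, with compound 1 nearby (a 1.2-fold lower number from compound 1 to compound 2 (0.07 log units; within the scatter)). Compound 3 `CC(C)[N+](C)(C)NCCC(=O)[O-]` carries isopropyl in place of allyl on an amine nitrogen. For the measured compounds named here, no measured step changes this position; the only step available, from compound 1 to compound 2, altered a different substituent and stayed within the scatter. For compound 3 no shift beyond the scatter is therefore expected, meaning a 1.1-fold higher number from compound 2 to compound 3 (0.04 log units; within the scatter). Compound 3 is accordingly estimated at 130000 nM, within 55000 nM to 320000 nM.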

Compound 3, half-maximal inhibitory concentration: > 1000000 nM
Compound 3: a limit, no number (the forecaster's own chance of this, stated with the estimate: 10%); at least 7.6-fold (0.88 log units) between middle value and limit.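

Compound 3 stands at a limit of the assay, not at a number: the limit of > 1000000 nM in this assay, at which 1 of the 3 values shown sits. For the compounds shown here, the position on the amine nitrogen, where the earlier compounds showed no change beyond the scatter, now responds: isopropyl in place of allyl gives an at least 8.4-fold higher number from compound 2 to compound 3 (0.92 log units; beyond the scatter), and methyl in place of hydrogen on the saturated chain carbon gives an at least 7.1-fold higher number from compound 1 to compound 3 (0.85 log units; beyond the scatter). Allyl and isopropyl each hold 3 heavy atoms, so that count does not separate them.

Going by these compounds, how far compound 3 lies past its limit stays open. So does whether a propyl, cyclopropyl or tert-butyl group on this nitrogen would follow allyl or isopropyl.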